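This account rests on a few compounds, and the source may have more. Where it says the series, first, only, none or still open, it means among the compounds named here.

Compound 1 `CCCCS(=O)(=O)N1CCC2(CC1)OOC1(CCCC1)OO2` and compound 2 `CCCCS(=O)(=O)N1CCC2(CC1)OOC1(CCCCCC1)OO2` share a butylsulfonyl group; the difference between their two cores is not broken down here. In a functional assay on Huh-7 cells (Homo sapiens) for cytotoxicity, read by MTT assay, with a stated time of 72 h (on this read-out higher numbers stand for lower toxicity in this test and lower numbers for higher toxicity in this test), compound 1 gives > 100 ug/mL, which is a limit of the assay and not a number. In this assay compound 2 gives > 100 ug/mL, again a limit. Compound 3 `O=S(=O)(CCCCl)N1CCC2(CC1)OOC1(CCCC1)OO2` carries the change chloro in place of methyl on a saturated chain carbon, three bonds along the chain from a sulfonyl sulfur on the core of compound 1. In this assay compound 3 gives > 100 ug/mL, also a limit. The step that the two limits leave unreadable from compound 1 to compound 3 therefore cannot be read, because the limit of > 100 ug/mL in this assay, at which 3 of the 3 values shown sit, holds every value shown.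

Compound 4 `O=S(=O)(CCCCl)N1CCC2(CC1)OOC1(CCCCCC1)OO2` applies the same change, (chloro in place of methyl on a saturated chain carbon, three bonds along the chain from a sulfonyl sulfur), to the core of compound 2. Since the place of the change is worded identically for both pairs, it is the same change. Compound 4 is expected to stay at the same limit, because the limit of > 100 ug/mL in this assay, at which 3 of the 3 values shown sit, is where all three values sit, so the expected step that the limit leaves unreadable from compound 2 to compound 4 is essentially nil. In this assay compound 4 is estimated at 150 ug/mL, between 100 ug/mL and 300 ug/mL.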

Compound 4, half-maximal cytotoxic concentration: > 100 ug/mL
Compound 4: only a limit was reported; the forecaster's own chance of this, stated with the estimate: 85%; the middle value does not contradict the limit.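

In this assay compound 4 gives > 100 ug/mL, which is a limit and not a number. No new step can be read from compound 2 to compound 4, because every value shown sits at one limit: the limit of > 100 ug/mL in this assay, at which 4 of the 4 values shown sit.

The compounds shown leave open whether chloro in place of methyl alters toxicity on either core, and how toxic any of these compounds is.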